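A few compounds are considered here, and "the series" means these few. Any claim that something is new, unique, unknown or untested is made for them only; others in the source may bear on it.

In a functional assay on HeLa cells (Homo sapiens) for inhibition, read by sulforhodamine B assay, with a stated time of 48 h (on this read-out higher numbers stand for weaker inhibition of growth and lower numbers for stronger inhibition of growth), compound 1 `O=C(CCC(F)(F)C(F)(F)C(F)(F)C(F)(F)F)NCCCCCCCCCN[C@@H]1[C@H](O)[C@@H](O)[C@H](O)[C@H]2COC(=O)N21` gives > 100000 nM, which is a limit of the assay and not a number. Among the measured compounds shown here, compound 2 `O=C(CCC(F)(F)C(F)(F)C(F)(F)C(F)(F)C(F)(F)C(F)(F)F)NCCCCCCCCCN[C@@H]1[C@H](O)[C@@H](O)[C@H](O)[C@H]2COC(=O)N21` gives 12000 nM, the only true number so far, so it has no measured neighbour to be ranked against on an exact scale. Compound 3 `O=C(CCC(F)(F)C(F)(F)C(F)(F)C(F)(F)C(F)(F)C(F)(F)C(F)(F)C(F)(F)F)NCCCCCCCCCN[C@@H]1[C@H](O)[C@@H](O)[C@H](O)[C@H]2COC(=O)N21` is not yet measured. It differs from compound 2 as follows: 1,1,2,2,2-pentafluoroethyl in place of fluoro on a saturated chain carbon bound to two fluorine atoms and a saturated chain carbon. In words, this is 1,1,2,2,2-pentafluoroethyl in place of fluoro on a saturated chain carbon bound to two fluorine atoms and a saturated chain carbon. The same change has been measured once, and it gave an at least 8.3-fold lower number from compound 1 to compound 2 (0.92 log units; beyond the scatter). That single step has a limit at one end, so it gives direction better than size. A somewhat smaller step towards stronger inhibition of growth is therefore expected in this assay. The estimated change is a 3.0-fold lower number from compound 2 to compound 3 (0.48 log units; beyond the scatter). For compound 3, the expected value is 4000 nM, within an estimated range of 1000 nM to 15000 nM.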

Compound 3, concentration for 50% growth inhibition: > 100000 nM
Compound 3: a limit, no number (the forecaster's own chance of this, stated with the estimate: 5%); middle value at least 25-fold (1.39 log units) away from the limit.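

In this assay, the change that went with stronger inhibition of growth at first, an at least 8.3-fold lower number from compound 1 to compound 2 (0.92 log units; beyond the scatter), turns in the opposite direction when repeated at the same position, giving an at least 8.3-fold higher number from compound 2 to compound 3 (0.92 log units; beyond the scatter). Compound 3 gives > 100000 nM, which is a limit of the assay and not a number, so this step has a known direction but no exact size. Extending the fluorinated chain end therefore does not act in one direction, and among these compounds only compound 2 gives a true number, while the others stop at one value: the limit of > 100000 nM in this assay, at which 2 of the 3 values shown sit.

Going by these compounds, how far compound 1 and compound 3 truly lie from compound 2 remains open. On these data alone, it is also open whether the fluorine atoms themselves matter, which an unfluorinated alkyl chain or a carboxylic acid at the chain end could help to test.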